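A Triple Hydroxyl Swap on the Hydrazone Arm

A few compounds are considered here, and "the series" means these few. Any claim that something is new, unique, unknown or untested is made for them only; others in the source may bear on it.

The compounds measured so far in a physicochemical assay, read by spectrophotometry, with a stated time of 6 min; on this read-out higher numbers stand for weaker inhibition and lower numbers for stronger inhibition:
compound 1 `O=C(CCc1nc2ccccc2c(=O)[nH]1)N/N=C/c1ccc(Cl)cc1` gives 185000000 nM
compound 2 `O=C(CCCc1nc2ccccc2c(=O)[nH]1)N/N=C/c1ccc([N+](=O)[O-])cc1` gives 270000000 nM
compound 3 `O=C(CCCc1nc2ccccc2c(=O)[nH]1)N/N=C/c1ccc(O)cc1` gives 170000000 nM

Compound 1 stands second highest of the three numbers in this assay; compound 3 is nearest and compound 2 furthest, and both gaps lie within the scatter. Compound 4 `O=C(CCc1nc2ccccc2c(=O)[nH]1)N/N=C/c1cc(O)c(O)c(O)c1` differs from compound 1 in one place: 3,4,5-trihydroxyphenyl in place of 4-chlorophenyl on a carbon with a double bond to nitrogen. Among the measured compounds shown here, the only measured step that bears on a hydroxy arriving on an aromatic carbon is a 1.6-fold lower number from compound 2 to compound 3 (0.20 log units; within the scatter), and it stays within the scatter. For the measured compounds named here, no measured pair brings in a 3,4,5-trihydroxyphenyl, so the step is expected to be small, leaning toward a lower number: a 1.5-fold lower number from compound 1 to compound 4 (0.19 log units; within the scatter). Compound 4 is therefore estimated at 120000000 nM, between 40000000 nM and 400000000 nM.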

Compound 4, half-maximal inhibitory concentration: 35000000 nM
The estimate for compound 4 lay 3.4-fold (0.54 log units) above the measured number; the measured number lies below the stated range.
By their numbers in this assay, from the lowest: compound 4; then compounds 3, 1 and 2 (each within the scatter of the next).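

In this assay, 3,4,5-trihydroxyphenyl in place of 4-chlorophenyl on a carbon with a double bond to nitrogen gives a 5.3-fold lower number from compound 1 to compound 4 (0.72 log units; beyond the scatter). This shows that a change at this position can move the number beyond the scatter, which the earlier step, a 1.6-fold lower number from compound 2 to compound 3 (0.20 log units; within the scatter), did not show. No measurement shown here accounts for the size of this step.

The compounds shown leave open whether all three hydroxy groups are needed for this step. They also leave open whether an amine or a carboxylic acid on the same aromatic ring would give a comparable step.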